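The source may hold more compounds than are shown below. What is called first, only, known or untested is meant among the compounds shown, and "the series" means these compounds.

Compound 1 `CCc1noc(C)c1[C@@H]1C[C@@](C)(c2ccc(F)cc2F)N=C(N)S1` gives 59%
Compound 2 `Cc1nocc1[C@@H]1C[C@@](C)(c2ccc(F)cc2F)N=C(N)S1` gives 77%
Compound 3 `Cn1nccc1[C@@H]1C[C@@](C)(c2ccc(F)cc2F)N=C(N)S1` gives 78%

In an ADME assay on microsomes from liver (Rattus norvegicus) for metabolic stability, with a stated time of 10 min, tested at 0.5 uM (on this read-out lower numbers stand for a less stable compound and higher numbers for a more stable compound), compound 3 stands at 78% within the scatter of compound 2 and beyond the scatter above compound 1. The next structure is compound 4 `C[C@@]1(c2ccc(F)cc2F)C[C@@H](c2cncnc2)SC(N)=N1` and the change to it is pyrimidin-5-yl in place of 1-methyl-1H-pyrazol-5-yl on a saturated ring carbon with pyrimidin-5-yl in place of 1-methyl-1H-pyrazol-5-yl on a saturated ring carbon. The nearest guide is a number 1 percentage points higher from compound 2 to compound 3 (within the scatter) where one aromatic group replaced another at this same place. The larger moves are a number 18 percentage points higher from compound 1 to compound 2 (beyond the scatter) and a number 19 percentage points higher from compound 1 to compound 3 (beyond the scatter) and both of them remove the 3-ethyl-5-methyl-1,2-oxazol-4-yl group, which plays no part in the present change. Going by the values given here, no measured compound carries a six-membered aromatic ring at this place, so the range must stay wide. Expected in this assay is a number 1 percentage points higher from compound 3 to compound 4 (within the scatter) and so no step beyond the scatter in either direction. For compound 4 the expected value is 79% with an estimated range from 65% to 92% as the likely span.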

Compound 4, percent of the compound remaining: 95%
Estimate against measurement, compound 4: 16 percentage points below; the measured number lies above the stated range.
By their numbers in this assay, from the lowest: compound 1; then compounds 2 and 3 (each within the scatter of the next); then compound 4.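

In this assay, pyrimidin-5-yl in place of 1-methyl-1H-pyrazol-5-yl on the saturated ring carbon next to the ring sulfur gives a number 17 percentage points higher from compound 3 to compound 4 (beyond the scatter), and in place of 3-methyl-1,2-oxazol-4-yl it gives a number 18 percentage points higher from compound 2 to compound 4 (beyond the scatter), so this position separates a six-membered aromatic ring from five-membered ones, although the first of these steps leaves the counts of heavy atoms, hetero atoms and hydrogen-bond acceptors unchanged. Against the 3-ethyl-5-methyl-1,2-oxazol-4-yl group, the same ring gives a number 36 percentage points higher from compound 1 to compound 4 (beyond the scatter), the largest step seen at this place. Nothing available explains why the six-membered ring stands apart.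

The compounds shown leave open whether the ring size alone or its two nitrogens carry the step; a phenyl or pyridin-3-yl group at this place would separate the two. Also open, from the compounds shown here alone, is whether a methyl or amino group on the pyrimidin-5-yl ring would keep this number.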